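Ethyl on the Amide Nitrogen of Compound 3

The source may hold more compounds than are shown below. What is called first, only, known or untested is meant among the compounds shown, and "the series" means these compounds.

Compound 3 `Cc1ccc(-n2nccn2)c(C(=O)N[C@@H](C)Cn2cc(-c3ccc(F)cn3)cn2)c1` stands at the weak end of the three measured compounds in a functional assay on cells for antagonist activity at Orexin/Hypocretin receptor type 1 (Homo sapiens), read by fluorescence and calcium flux, with a stated time of 30 min; a higher number here means a weaker inhibitor, a lower number a stronger inhibitor. Compound 3 gives 245 nM, the highest number of the set. Compound 2 `Cc1ccc(-n2nccn2)c(C(=O)N(C)CCn2ccc(-c3ccc(F)cn3)n2)c1` gives 5.54 nM, and compound 1 `CCN(C(=O)c1cc(C)ccc1-n1nccn1)[C@@H](C)Cn1ccc(-c2ccc(F)cn2)n1` gives 1.62 nM; both numbers lie far below that of compound 3, and the gaps are well beyond the scatter. Compounds 1 and 2 differ from compound 3 in more than one place, so their values show only that tertiary amides of this kind can reach low numbers in this assay, not which single change is responsible.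

Compound 4 `CCN(C(=O)c1cc(C)ccc1-n1nccn1)[C@@H](C)Cn1cc(-c2ccc(F)cn2)cn1` is reached from compound 3 by one change: ethyl in place of hydrogen on an amide-type nitrogen. Within the data shown here, no measured pair isolates this change, since compound 1 also differs from compound 4 in how the aryl group sits on its ring. The expectation is therefore a step downward in this assay, of a size larger than the scatter but smaller than the full gap between compound 3 and compound 1. The expected step is a 6.1-fold lower number from compound 3 to compound 4 (0.79 log units; beyond the scatter). On that basis compound 4 is estimated at 40 nM, with a range from 8 nM to 200 nM.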

Compound 4, half-maximal inhibitory concentration: 0.767 nM
For compound 4 the middle estimate is 52-fold (1.72 log units) above the measured one, outside the stated range (below it).
By their numbers in this assay, from the lowest: compound 4; then compound 1; then compound 2; then compound 3.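

In this assay, among these compounds, the amide hydrogen of compound 3 proves not to be required: ethyl in its place on the amide-type nitrogen gives a 320-fold lower number from compound 3 to compound 4 (2.50 log units; beyond the scatter) and is the first measured pair in which this single change stands alone. Compound 1 and compound 2 each differ from compound 3 in more than one place, so they could only suggest that tertiary amides reach low numbers, whereas this pair shows such a drop on the core of compound 3 with nothing else altered. Nothing available here bears on the reason for the size of this step.

As far as these compounds go, only hydrogen and ethyl can be compared at this nitrogen on this core, so it stays open how methyl, a longer chain such as propyl, or a cyclopropyl ring would behave there. From the compounds shown here alone, it also stays open whether ethyl brings a step of similar size when the aryl group sits on its ring as in compound 1, since telling that would take the counterpart of compound 1 with the amide hydrogen.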